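The compounds below may be only part of what the source reports. "The series", "measured", "known", "first", "only" and "open" are said of these compounds alone.

For the measured compounds named here, compound 2 `CCc1ccc(NC(=O)N[C@H](C)c2ccccc2)cc1` gives 44% in an ADME assay on the whole organism with Oryza sativa as the target, tested at 10 uM (a lower number here means a stronger effect, a higher number a weaker effect of the compound at the concentration tested), the lowest of the three numbers measured so far. Compound 1 `CCc1ccccc1NC(=O)N[C@@H](C)c1ccccc1` gives 95% in this assay, and compound 3 `CCc1ccc(NC(=O)N[C@@H](C)c2ccccc2)cc1` gives 91%. Going by the values given here, the only step measured between compounds that differ in one place is a number 47 percentage points higher from compound 2 to compound 3 (beyond the scatter), and it rests on (the fact that compounds 2 and 3 differ only in the configuration as drawn), a change in configuration and nothing more.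

Compound 4 `CCCCc1ccc(NC(=O)N[C@H](C)c2ccccc2)cc1` departs from compound 2 in a different way: ethyl in place of hydrogen on a saturated chain carbon, two bonds along the chain from an aromatic carbon, so that ethyl becomes butyl on the core shared with compound 2. Among the compounds with values here, no measured step touches this chain, and the one step that has been measured concerns configuration alone, so it gives no guide to the direction or the size of the present change. The account therefore expects the step of a number 8 percentage points higher from compound 2 to compound 4 (within the scatter) to stay within the usual scatter, with no direction it can defend from the numbers at hand. For compound 4 the estimate in this assay is 52%, expected to fall between 20% and 88%, a wide range that reflects how little the three measured compounds say about a longer chain at this place.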

Compound 4, a percentage reported as activity, at one concentration (the size of the read-out at that concentration, not a potency): 28%
Estimate against measurement, compound 4: 24 percentage points above; low and high end bracket the measured number.
By their numbers in this assay, from the lowest: compound 4; then compound 2; then compounds 3 and 1 (each within the scatter of the next).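

In this assay, for the compounds shown here, the longer chain gives a number 16 percentage points lower from compound 2 to compound 4 (beyond the scatter), so this position, which no earlier step touched, responds to a change in the chain alone, and the response is towards a stronger effect at the concentration tested. Going by these compounds alone, this is the first sign that the shared core can be altered away from its stereocentre with a gain rather than a loss, although the single step from ethyl to butyl is too little to establish a trend with chain length, and it is modest in size beside a number 47 percentage points higher from compound 2 to compound 3 (beyond the scatter). What is known about these compounds concerns only their configuration and does not bear on the change from ethyl to butyl, so the result has no explanation from the data at hand.

On these data alone, it remains open whether a longer chain such as hexyl, or an amine or a carboxylic acid in place of butyl, would take the number further down or bring it back up. As far as these compounds go, it is also open whether the butyl compound with its stereocentre drawn S would show a step of the kind seen for the ethyl pair.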